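Sulfoxide thienopyridines: swapping an amide for a sulfonamide

The source may hold more compounds than are shown below. What is called first, only, known or untested is meant among the compounds shown, and "the series" means these compounds.

Measured compounds:
- compound 1 `CCCC[S+]([O-])c1sc2nc(-c3nccs3)cc(-c3ccc(C(=O)N(C)C)cc3)c2c1N`: 5.9 nM
- compound 2 `Nc1c([S+]([O-])CCCF)sc2nc(-c3cccs3)cc(-c3ccccc3)c12`: 6.1 nM

In an assay for inhibition of 15-hydroxyprostaglandin dehydrogenase [NAD(+)] (Homo sapiens), read by fluorescence, with a stated time of 15 min, in the presence of a further agent that is not named here (a higher number here means a weaker inhibitor, a lower number a stronger inhibitor), compound 1 gives 5.9 nM. Compound 2, with a different core decoration, gives 6.1 nM in this assay, and the two numbers lie within the scatter of each other, so neither can be set apart from the other. Compound 1 has the lowest of the two numbers shown, but only by a margin that carries no meaning.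

Compound 3 `CCCC[S+]([O-])c1sc2nc(-c3nccs3)cc(-c3ccc(CNS(C)(=O)=O)cc3)c2c1N` differs from compound 1 in one place: (methanesulfonamido)methyl in place of dimethylcarbamoyl on an aromatic carbon. Among the compounds with values here, no measured pair shows the effect of this exchange, so the expectation rests on compound 1 alone. A step from compound 1 to compound 3 of a 1.5-fold higher number from compound 1 to compound 3 (0.18 log units; within the scatter) is expected, in the direction of a weaker inhibitor, of a size not clearly beyond the scatter. Compound 3 is expected to give 9 nM in this assay, within a range from 3 nM to 30 nM.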

Compound 3, half-maximal inhibitory concentration: 4.6 nM
Compound 3: middle estimate off by 2.0-fold (0.29 log units), on the high side; the measured number falls inside the stated range.
By their numbers in this assay, from the lowest: compounds 3, 1 and 2 (each within the scatter of the next).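

In this assay, placing (methanesulfonamido)methyl instead of dimethylcarbamoyl on the aromatic carbon para to a large group gives a 1.3-fold lower number from compound 1 to compound 3 (0.11 log units; within the scatter), so the two groups cannot be told apart here. Within the data shown here, this is the first reading of any change at this position, and it shows that a larger group carrying a hydrogen-bond donor, which dimethylcarbamoyl lacks, leaves the number within the scatter. No separate measurement bears on this result.

Going by these compounds, two groups of similar size say little about how much this position accepts, so it remains open whether a carboxylic acid or an aminomethyl group would also leave the number within the scatter. On these data alone, it is also open whether the same exchange would behave alike with a longer chain on the sulfoxide.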